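Moving the methoxy of compound 1 onto the fused ring

The compounds below may be only part of what the source reports. "The series", "measured", "known", "first", "only" and "open" are said of these compounds alone.

Compound 1 `Cc1ccc(C2CC(=O)c3ccc(C)cc3O2)cc1` gives 500 nM in an in vitro assay on BTI-TN-5B1-4 cells for inhibition of Amine oxidase [flavin-containing] B (Homo sapiens) (on this read-out higher numbers stand for weaker inhibition and lower numbers for stronger inhibition), the lowest number among the three measured compounds. Compound 3 `Cc1ccc([C@H]2CC(=O)c3ccc(C)cc3O2)cc1` gives 530 nM, and the step of a 1.1-fold higher number from compound 1 to compound 3 (0.03 log units; within the scatter) lies within the scatter; the fact that one of compounds 1 and 3 is drawn with a defined configuration and the other without, at the place where they differ is all that separates the two. Compound 2 `COc1ccc(C2CC(=O)c3ccc(C)cc3O2)cc1` gives 3350 nM, so a 6.7-fold higher number from compound 1 to compound 2 (0.83 log units; beyond the scatter) weakens inhibition modestly. Compound 4 `COc1ccc2c(c1)OC(c1ccc(C)cc1)CC2=O` carries the same exchange, (methoxy in place of methyl on an aromatic carbon), but at a different place, on a ring that is part of a fused or bridged system of two rings. Going by the values given here, only the step from compound 1 to compound 2 bears on this change, and it was measured at another position, so a modest weakening is expected, with wide uncertainty. Compound 4 is therefore expected to give 1500 nM (range 400 nM to 6000 nM), an estimated step of a 3.0-fold higher number from compound 1 to compound 4 (0.48 log units; beyond the scatter).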

Compound 4, half-maximal inhibitory concentration: 550 nM
Beside the measured number, compound 4's estimate is 2.7-fold (0.44 log units) above it; the range from low to high includes it.
By their numbers in this assay, from the lowest: compounds 1, 3 and 4 (each within the scatter of the next); then compound 2.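

On the ring that is part of the fused system, methoxy in place of methyl gives a 1.1-fold higher number from compound 1 to compound 4 (0.04 log units; within the scatter) and so leaves inhibition unchanged within the scatter, whereas the same exchange at the position in compound 2 gives a 6.7-fold higher number from compound 1 to compound 2 (0.83 log units; beyond the scatter) and weakens it. Across these compounds, then, the outcome of this exchange depends on where it is made. Nothing shown accounts for that difference. On these data alone, whether a longer chain such as ethoxy, an amine or a carboxylic acid would be accepted on this aromatic carbon remains open.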